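Trading methoxy for vinyl on a shared core

The source may report more compounds than this note shows. Statements on the series, on what has been measured and on what is new or still open speak of the compounds shown alone.

Three measured compounds share one core. Compound 1 `COc1cc(-c2ccnc3cc(-c4ccc5cc[nH]c5c4)nn23)cc(OC)c1OC` gives 125 nM in a functional assay on HeLa cells (Homo sapiens) for inhibition, read by CCK-8 assay, with a stated time of 48 h; a lower number here means a stronger inhibitor, a higher number a weaker inhibitor. Compound 2 `COc1cc(-c2ccnc3cc(-c4ccc(C(C)(C)C)cc4)nn23)cc(OC)c1OC` reaches only the assay limit of > 10000 nM in this assay. Compound 3 `COc1ccc(-c2cc3nccc(-c4cc(OC)c(OC)c(OC)c4)n3n2)cc1` gives 373 nM in this assay, the higher of the two plain numbers, its nearest neighbour being compound 1 with a 3.0-fold higher number from compound 1 to compound 3 (0.47 log units; beyond the scatter).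

Compound 4 `C=Cc1ccc(-c2cc3nccc(-c4cc(OC)c(OC)c(OC)c4)n3n2)cc1` differs from compound 3 in one place: vinyl in place of methoxy on an aromatic carbon. The step that bears on this is an at least 26-fold lower number from compound 2 to compound 3 (1.42 log units; beyond the scatter), which shows that replacing methoxy on this aromatic carbon with a hydrocarbon group costs a great deal. Vinyl, like tert-butyl, carries no hydrogen-bond acceptor, so a weaker number is expected in this assay, though vinyl is smaller and the loss may be less severe. Compound 4 is therefore expected to give 1500 nM, between 400 nM and 8000 nM. The expected step is a 4.0-fold higher number from compound 3 to compound 4 (0.60 log units; beyond the scatter).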

Compound 4, half-maximal inhibitory concentration: 882 nM
The estimate for compound 4 lay 1.7-fold (0.23 log units) above the measured number; low and high end bracket the measured number.
By their numbers in this assay, from the lowest: compound 1; then compound 3; then compound 4. At a limit, above all of these: compound 2.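

In this assay, vinyl costs only a modest step against methoxy, with a 2.4-fold higher number from compound 3 to compound 4 (0.37 log units; beyond the scatter), and the 4-vinylphenyl compound also stays modestly behind the 1H-indol-6-yl compound, with a 7.1-fold higher number from compound 1 to compound 4 (0.85 log units; beyond the scatter). A group with no hydrogen-bond acceptor can therefore stand on this aromatic carbon without the large loss seen with tert-butyl, with an at least 11-fold lower number from compound 2 to compound 4 (1.05 log units; beyond the scatter). Compound 2 holds a limit, not a number: the limit of > 10000 nM in this assay, at which 1 of the 4 values shown sits.

On these data alone, whether ethyl, an amine or a carboxylic acid on this aromatic carbon would give a lower number than compound 3 stays open.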